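The source may report more compounds than this note shows. Statements on the series, on what has been measured and on what is new or still open speak of the compounds shown alone.

Compound 1 `CC(=O)Oc1ccccc1C(=O)O[C@H]1CO[C@H]2[C@@H]1OC[C@H]2OC(=O)c1ccnn1C` gives 0.0963 h in an ADME assay on a cell-free system (plasma, Homo sapiens) for metabolic stability, with Plasma (Rattus norvegicus) as the target, read by HPLC, at pH 7.4; a lower number here means that the compound disappears faster, a higher number that the compound lasts longer.
Compound 2 `CC(=O)Oc1ccccc1C(=O)O[C@H]1CO[C@H]2[C@@H]1OC[C@H]2OC(=O)c1cccc(O)c1` gives 0.0183 h in this assay.
Compound 3 `COc1ccccc1C(=O)O[C@@H]1CO[C@H]2[C@@H]1OC[C@@H]2OC(=O)c1ccccc1OC(C)=O` gives 0.0578 h in this assay.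

Compound 3 stands second highest of the three: a 1.7-fold lower number from compound 1 to compound 3 (0.22 log units; within the scatter) keeps it close to compound 1, while a 3.2-fold higher number from compound 2 to compound 3 (0.50 log units; beyond the scatter) separates it clearly from compound 2. Compound 4 `CC(=O)Oc1ccccc1C(=O)O[C@H]1CO[C@H]2[C@@H]1OC[C@H]2OC(=O)c1cc(C)nc(Cl)c1` is the next step from compound 3: 2-chloro-6-methylpyridin-4-yl in place of 2-methoxyphenyl on a carbonyl carbon. For the measured compounds named here, the two measured steps that bear on it both change the ring on this same carbonyl carbon, and only the step from compound 2 was beyond the scatter. Going by the values given here, no measured compound carries a pyridinyl ring here, so the change is expected to stay within the scatter, a 1.0-fold higher number from compound 3 to compound 4 (0.02 log units; within the scatter). Compound 4 is therefore estimated at 0.06 h in this assay, between 0.02 h and 0.15 h.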

Compound 4, half-life: 0.0193 h
For compound 4 the middle estimate is 3.1-fold (0.49 log units) above the measured one; the whole stated range lies above it.
By their numbers in this assay, from the lowest: compounds 2 and 4 (each within the scatter of the next); then compounds 3 and 1 (each within the scatter of the next).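

On this carbonyl carbon, a swap that keeps 8 heavy atoms still shifts the half-life in this assay, with a 3.0-fold lower number from compound 3 to compound 4 (0.48 log units; beyond the scatter) for this change alone. The pyridinyl ring also joins the short-lived end of the set, with a 5.0-fold lower number from compound 1 to compound 4 (0.70 log units; beyond the scatter) but only a 1.1-fold higher number from compound 2 to compound 4 (0.02 log units; within the scatter) on the same carbon. Nothing available here explains these shifts.

From the compounds shown here alone, the chlorine, the methyl and the ring nitrogen all enter together, and which of them carries the step stays open. So does the half-life of a ring bearing an amine or a carboxylic acid.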